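Following the Step from Compound 1 to Compound 4

The source may report more compounds than this note shows. Statements on the series, on what has been measured and on what is new or still open speak of the compounds shown alone.

Measured in a functional assay on HL-60 cells (Homo sapiens) for inhibition, read by CCK-8 assay, with a stated time of 48 h; on this read-out higher numbers stand for weaker inhibition and lower numbers for stronger inhibition:
- compound 1 `COc1ccc(NC(=O)NCCNS(=O)(=O)c2ccc(-c3ccccc3OCc3ccccc3)s2)cc1`: > 50000 nM (a limit, not a number)
- compound 2 `O=S(=O)(NCCNC(=S)Nc1cc(C(F)(F)F)cc(C(F)(F)F)c1)c1cc(-c2ccccc2Oc2ccc(O)c(O)c2)cs1`: 600 nM
- compound 3 `O=C(NCCNS(=O)(=O)c1ccc(-c2ccccc2Oc2ccc([N+](=O)[O-])c([N+](=O)[O-])c2)s1)Nc1cc(Cl)cc(Cl)c1`: 2300 nM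

In this assay compound 1 stands at > 50000 nM, which is a limit of the assay and not a number. The account follows the step from compound 1 to compound 4 `O=C(NCCNS(=O)(=O)c1ccc(-c2ccccc2OCc2ccccc2)s1)Nc1cccc([N+](=O)[O-])c1`, which has yet to be measured. The structural change reads (3-nitrophenyl in place of 4-methoxyphenyl on an amide-type nitrogen). Put briefly, 3-nitrophenyl takes the place of 4-methoxyphenyl on an amide-type nitrogen.

Among the measured compounds shown here, no step between measured compounds is available to size this change, so the expectation rests on the values alone. Compound 2 at 600 nM and compound 3 at 2300 nM show that measured numbers do occur among these compounds. On that ground, compound 4 is expected to inhibit more strongly than compound 1, although it could still return only a limit. The expected change is an at least 8.3-fold lower number from compound 1 to compound 4 (0.92 log units; beyond the scatter), in the direction of stronger inhibition. In this assay the estimate for compound 4 is 6000 nM, with an expected range from 1500 nM to 30000 nM.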

Compound 4, half-maximal inhibitory concentration: 2800 nM
Beside the measured number, compound 4's estimate is 2.1-fold (0.33 log units) above it; the range from low to high includes it.
By their numbers in this assay, from the lowest: compound 2; then compounds 3 and 4 (each within the scatter of the next). At a limit, above all of these: compound 1.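

In this assay, among the compounds shown here, 3-nitrophenyl in place of 4-methoxyphenyl on an amide-type nitrogen gives an at least 17-fold lower number from compound 1 to compound 4 (1.25 log units; beyond the scatter) and is the first change in one place that can be read here. Compounds 2 and 3 carried measured numbers but differed from compound 1 in more than one place, which left open whether the group on this nitrogen mattered at all; this step shows that exchanging that one group, with the rest of compound 1 kept, is enough to move a compound from a limit to a measured number. The value of compound 1 is a limit and not a number: the limit of > 50000 nM in this assay, at which 1 of the 4 values shown sits.

The compounds shown leave open whether the step belongs to the arrival of the nitro group, to the loss of the methoxy group, or to the different place of the group on the ring. They also do not tell how a plain phenyl on the same nitrogen would read in this assay or what an amine or a carboxylic acid in place of the nitro group would do there.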